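This account rests on a few compounds, and the source may have more. Where it says the series, first, only, none or still open, it means among the compounds named here.

Measured so far in a functional assay on HCC827 cells (Homo sapiens) for inhibition, read by MTT assay, with a stated time of 48 h, tested at 10 uM; on this read-out higher numbers stand for more inhibition at the one concentration tested (going by the name of the read-out) and lower numbers for less inhibition:
- compound 1 `COc1cc(NC(=O)Nc2cc(Nc3ccc(OC)c(C)c3)ncn2)cc(OC)c1`: 48.3%
- compound 2 `COc1ccc(Br)cc1Nc1cc(NC(=O)Nc2c(Cl)cccc2Cl)ncn1`: 53%
- compound 3 `COc1ccc(OC)c(Nc2cc(NC(=O)Nc3c(Cl)cccc3Cl)ncn2)c1`: 94.1%

Compound 2 sits in the middle of the three numbers: compound 1 lies within the scatter of it, while a number 41.1 percentage points higher from compound 2 to compound 3 (beyond the scatter) is a large step beyond the scatter. Compound 4 `O=C(Nc1cc(Nc2ccc(F)c(Cl)c2)ncn1)Nc1c(Cl)cccc1Cl` is not yet measured. It differs from compound 2 in one place: 3-chloro-4-fluorophenyl in place of 5-bromo-2-methoxyphenyl on a nitrogen on an aromatic ring. Within the data shown here, the only measured step at this ring, a number 41.1 percentage points higher from compound 2 to compound 3 (beyond the scatter), concerns a different change (methoxy in place of bromo) and so bears on compound 4 only indirectly, showing that this ring can move the read-out strongly; no step tells the direction for the present change. A step of a number 7 percentage points higher from compound 2 to compound 4 (within the scatter) is therefore expected, not beyond the scatter. Compound 4 is estimated at 60% (range 30% to 90%).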

Compound 4, a percentage reported as inhibition, at one concentration (the size of the read-out at that concentration, not a potency): 53.7%
The estimate for compound 4 lay 6.3 percentage points above the measured number; measured number inside the range.
By their numbers in this assay, from the lowest: compounds 1, 2 and 4 (each within the scatter of the next); then compound 3.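

In this assay, 3-chloro-4-fluorophenyl in place of 5-bromo-2-methoxyphenyl on a nitrogen on an aromatic ring gives a number 0.7 percentage points higher from compound 2 to compound 4 (within the scatter). Among these compounds, the whole aryl group at this position can therefore be exchanged, losing both methoxy and bromo, without a difference beyond the scatter, whereas the single change in a number 41.1 percentage points higher from compound 2 to compound 3 (beyond the scatter) is large. No measurement available here explains this contrast.

Still open, on these data alone, is how an amine or a carboxylic acid on this aryl ring would affect the read-out. Among the compounds shown here, also open is whether a second methoxy added to the 3-chloro-4-fluorophenyl ring would give a step as large as the one to compound 3.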